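The compounds below may be only part of what the source reports. "The series", "measured", "known", "first", "only" and "open" are said of these compounds alone.

Compound 1 `O=C(NCc1ccc(CNS(=O)(=O)c2ccccc2F)cc1)c1cccnc1` gives 100 nM in an assay on MDA-MB-231 cells for displacement of a labelled ligand from C-X-C chemokine receptor type 4 (Homo sapiens), read by fluorescence and microscopy, with stated times of 10 min and 30 min; a lower number here means that less compound is needed, a higher number that more compound is needed for the effect
Compound 2 `COc1ccccc1C(=O)NCc1ccc(CNS(=O)(=O)c2ccccc2F)cc1` gives 1 nM in this assay

Of these two numbers, compound 1 stands highest; its nearest neighbour is compound 2, and the step of a 100-fold lower number from compound 1 to compound 2 (2.00 log units; beyond the scatter) shows that exchanging the group on the carbonyl carbon moved the number a long way. Compound 3 `Cc1cccc(S(=O)(=O)NCc2ccc(CNC(=O)c3cccnc3)cc2)c1` has not yet been measured. It differs from compound 1 at the other end of the shared core: 3-methylphenyl in place of 2-fluorophenyl on a sulfonyl sulfur. For the measured compounds named here, the only measured step, the one from compound 1 to compound 2, concerns the carbonyl side and leaves the sulfonyl side untouched, so it gives no guide to what a change at the sulfonyl sulfur does. Nothing in the data shows whether this part of the molecule is sensitive at all. Going by the values given here, with no comparable step to lean on, the plain expectation is that compound 3 will land close to compound 1, with a step of no change at the digits printed from compound 1 to compound 3 (within the scatter) that is expected to stay within the scatter. Compound 3 is therefore estimated at 100 nM, with a range from 30 nM to 300 nM.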

Compound 3, effective concentration (reported as EC, without a stated level of effect): 10 nM
Estimate against measurement, compound 3: 10-fold (1.00 log units) above; the whole stated range lies above it.
By their numbers in this assay, from the lowest: compound 2; then compound 3; then compound 1.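

The sulfonyl end of the molecule turns out to be sensitive as well: with the carbonyl side held as pyridin-3-yl, placing 3-methylphenyl instead of 2-fluorophenyl on the sulfonyl sulfur gives a 10-fold lower number from compound 1 to compound 3 (1.00 log units; beyond the scatter) in this assay. Until now, only the carbonyl side had been seen to move the number, so both ends of the shared core now respond to change. The size of this step stands out, given that the two groups have the same heavy-atom count, the same kind of ring, no hydrogen-bond donors or acceptors and no net charge, although nothing shown explains why the number moved.

The swap removes a fluorine and adds a methyl in a single step, so the effect of each remains unresolved, and a plain unsubstituted phenyl on the sulfonyl sulfur would help to tell them apart. Also open, on these data alone, is how this position would respond to a quite different group on the ring, such as an amine or a carboxylic acid, and whether the gain seen here would carry over to the 2-methoxyphenyl series.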